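From 4-methoxyphenyl to 2-methoxyphenyl on the ring nitrogen

A few compounds are considered here, and "the series" means these few. Any claim that something is new, unique, unknown or untested is made for them only; others in the source may bear on it.

Measured compounds:
- compound 1, `CN1CCN(CC(=O)Nc2nc3ccccc3[nH]2)CC1`: in a functional assay, read by spectrophotometry, with a stated time of 30 min, tested at 5 ug/mL (a lower number here means a weaker effect, a higher number a stronger effect of the compound at the concentration tested), compound 1 gives 11%
- compound 2, `COc1ccc(N2CCN(CC(=O)Nc3nc4ccccc4[nH]3)CC2)cc1`: in this assay compound 2 gives 7.24%

Among the compounds with values here, only two compounds have numbers so far, and they lie close together: the single step measured, a number 3.8 percentage points lower from compound 1 to compound 2 (within the scatter), came with the exchange of a methyl for a 4-methoxyphenyl on an amine nitrogen in a ring. Compound 2 therefore stands next to compound 1 with nothing to separate the two beyond the usual spread of this kind of measurement.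

Compound 3, `COc1ccccc1N1CCN(CC(=O)Nc2nc3ccccc3[nH]2)CC1`, is built from the same atoms as compound 2, joined differently: 2-methoxyphenyl in place of 4-methoxyphenyl on an amine nitrogen in a ring. Within the data shown here, no measured step concerns a change of this kind; the one step available swaps a methyl for an aryl group, not one methoxyphenyl for another, so it offers no direct guide. Among the measured compounds shown here, with the only measured step within the scatter and both numbers small, compound 3 is expected to give 8% in this assay, in the range 2% to 17%, which means an expected step of a number 0.8 percentage points higher from compound 2 to compound 3 (within the scatter), no larger than the scatter.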

Compound 3, a percentage reported as activity, at one concentration (the size of the read-out at that concentration, not a potency) in the functional assay: 10.8%
For compound 3 the middle estimate is 2.8 percentage points below the measured one; low and high end bracket the measured number.
By their numbers in the functional assay, from the lowest: compounds 2, 3 and 1 (each within the scatter of the next).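

In the functional assay, 2-methoxyphenyl in place of 4-methoxyphenyl gives a number 3.6 percentage points higher from compound 2 to compound 3 (within the scatter), and 2-methoxyphenyl in place of methyl gives a number 0.2 percentage points lower from compound 1 to compound 3 (within the scatter), so on this amine nitrogen in a ring, this read-out separates neither methoxyphenyl group from the other, nor 2-methoxyphenyl from methyl. The exchange of one methoxyphenyl group for the other is nevertheless far from silent, even though the two compounds are built from the same atoms, as a physicochemical assay for lipophilicity, read by spectrophotometry, using the shake flask method, measured as octanol-water partition, with a stated time of 24 h (on this read-out higher numbers stand for higher lipophilicity and lower numbers for lower lipophilicity), shows: the measured partition coefficient of compound 2, 2.65, and of compound 3, 0.97, a number 1.68 log units lower (beyond the scatter). In the physicochemical assay compound 2 gives 2.65 and compound 3 gives 0.97 as its partition coefficient. For this one pair, then, a large step in lipophilicity comes with no step beyond the scatter in the functional assay, so the lipophilicity of these two compounds does not show up in that read-out at the single concentration tested.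

Three compounds cannot show whether this flat picture holds for groups of another kind on the same nitrogen, such as a longer alkyl chain or a phenyl ring carrying a carboxylic acid. Going by these compounds, it also remains open which change to the shared core or to the group on this nitrogen, if any, would carry the numbers in the functional assay beyond the scatter.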